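Cyclopropyl for methyl on the five-membered ring of compound 2

This account rests on a few compounds, and the source may have more. Where it says the series, first, only, none or still open, it means among the compounds named here.

Compound 1: `NCC(=O)NCc1nncn1-c1ccc(Cl)cc1C(=O)c1ccccc1`; 1.66 mg/kg
Compound 2: `Cc1nnc(CNC(=O)CN)n1-c1ccc(Cl)cc1C(=O)c1ccccc1Cl`; 0.62 mg/kg
Compound 3: `CN(C(=O)CNC(=O)CN)c1ccc(Cl)cc1C(=O)c1ccccc1Cl`; 2.59 mg/kg

In a functional assay on the whole organism with Mus musculus as the target (a lower number here means that less compound is needed, a higher number that more compound is needed for the effect), compound 2 gives the lowest number of the three, and its steps to both compound 1 and compound 3 lie beyond the scatter, so it counts as the most potent of the measured set. Compound 4, `NCC(=O)NCc1nnc(C2CC2)n1-c1ccc(Cl)cc1C(=O)c1ccccc1Cl`, differs from compound 2 only on the five-membered aromatic ring with 3 nitrogen: cyclopropyl in place of methyl on an aromatic carbon. No measured pair shows this kind of change, so its size cannot be read from the shown steps. The expectation is that the step of a 1.1-fold higher number from compound 2 to compound 4 (0.05 log units; within the scatter) stays within the scatter, with no clear direction. Compound 4 is therefore estimated at 0.7 mg/kg, with a range from 0.3 mg/kg to 1.6 mg/kg.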

Compound 4, dose for half-maximal effect: 0.49 mg/kg
Compound 4: the middle estimate sits 1.4-fold (0.15 log units) above what was measured, within the range that was stated.
By their numbers in this assay, from the lowest: compounds 4 and 2 (each within the scatter of the next); then compounds 1 and 3 (each within the scatter of the next).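

In this assay, the aromatic carbon between two ring nitrogen atoms takes cyclopropyl in place of methyl with a 1.3-fold lower number from compound 2 to compound 4 (0.10 log units; within the scatter), so three heavy atoms and a three-membered ring instead of one heavy atom give no readable difference. Among the compounds shown here, this is the first pair in the set to isolate a change at this position. Nothing measured here accounts for the result. Still open, going by these compounds, is whether this position would equally take a group bearing an amine or a carboxylic acid, or a longer chain such as n-butyl.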